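Swapping a Dichlorobenzyl Arm for a Methoxybenzyl Arm

This account rests on a few compounds, and the source may have more. Where it says the series, first, only, none or still open, it means among the compounds named here.

The three measured compounds share one core. Compound 1 `Nc1cc(N)c2nc(-c3ccccc3)c(Oc3ccc(Cl)c(Cl)c3)nc2c1` links its aromatic side arm to that core through an oxygen, and in a functional assay on KM12 cells (Homo sapiens) for inhibition, read by sulforhodamine B assay, with a stated time of 48 h (on this read-out lower numbers stand for stronger inhibition of growth and higher numbers for weaker inhibition of growth), compound 1 gives 6310 nM. Compound 3 `Nc1cc(N)c2nc(-c3ccccc3)c(NCc3ccc(Cl)c(Cl)c3)nc2c1` links a 3,4-dichlorobenzyl group through a nitrogen instead; in this assay compound 3 gives 3390 nM, a value that lies within the usual scatter of the value of compound 1, so the two stand together and no trustworthy difference separates them. Compound 2 `CCOC(=O)[C@H](CCC(=O)O)NC(=O)c1ccc(CNc2nc3cc(N)cc(N)c3nc2-c2ccccc2)cc1` carries a much larger side arm, and in this assay compound 2 reaches only a limit of < 100000 nM, which is not a measured number.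

Compound 4 `COc1ccc(CNc2nc3cc(N)cc(N)c3nc2-c2ccccc2)cc1` has not yet been measured. It differs from compound 3 in one place: 4-methoxyphenyl in place of 3,4-dichlorophenyl on a saturated chain carbon bound to a nitrogen on an aromatic ring. Among the compounds with values here, no measured pair shows this exact change, so the step expected here, a 1.8-fold higher number from compound 3 to compound 4 (0.25 log units; within the scatter), rests on judgement alone and points toward somewhat weaker inhibition of growth, though a shift within the scatter is just as possible. Compound 4 is estimated at 6000 nM, with a range from 1500 nM to 25000 nM.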

Compound 4, concentration for 50% growth inhibition: 13200 nM
Compound 4: the middle estimate sits 2.2-fold (0.34 log units) below what was measured; measured number inside the range.
By their numbers in this assay, from the lowest: compounds 3 and 1 (each within the scatter of the next); then compound 4.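

This is the first comparison among the compounds shown in which the arm changes in only one place, and in this assay it gives a 3.9-fold higher number from compound 3 to compound 4 (0.59 log units; beyond the scatter). The ring on this arm is therefore not a neutral spectator: what it carries can shift the growth-inhibition number by more than the usual scatter. The shift appears even though 3,4-dichlorophenyl and 4-methoxyphenyl each hold 8 heavy atoms, so the two groups differ in their atoms and not in that count.

Still open, on these data alone, is whether losing the two chlorines or gaining the methoxy matters more, a question that plain phenyl or 4-chlorophenyl on the same chain carbon would help to settle. Nothing measured here explains the step.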